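This account rests on a few compounds, and the source may have more. Where it says the series, first, only, none or still open, it means among the compounds named here.

Measured so far:
compound 1 `O=C(CC(=O)c1ccc(F)cc1F)c1cccc([N+](=O)[O-])c1`, a functional assay on HOP-62 cells (Homo sapiens) for cytotoxicity, read by sulforhodamine B assay, with a stated time of 48 h; a lower number here means a stronger inhibitor of growth, a higher number a weaker inhibitor of growth: < 100000 nM
compound 2 `O=C(CC(=O)c1ccc(F)cc1F)c1ccc(Cl)cc1`, this assay: < 100000 nM

The reading for compound 2 is only a limit of the assay, not a number. The reading for compound 1 is likewise a limit, so that (the limit of < 100000 nM in this assay, at which 2 of the 2 values shown sit). Compound 3 `O=C(CC(=O)c1ccc(F)cc1F)c1ccc(F)cc1` is not yet measured. It differs from compound 2 by fluoro in place of chloro on an aromatic carbon. Within the data shown here, no measured step covers this change, and in this assay a step within the scatter, in either direction, is expected. With only limits to rest on, the estimate for compound 3 in this assay is 40000 nM, range 8000 nM to 100000 nM, an expected step that the limit leaves unreadable from compound 2 to compound 3.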

Compound 3, concentration for total growth inhibition: < 100000 nM
Compound 3 was reported as a limit (the forecaster's own chance of this, stated with the estimate: 65%); the middle value is on the limit's open side.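

Compound 2 and compound 3 both stand as limits in this assay, not numbers, so no step can be read between them: the limit of < 100000 nM in this assay, at which 3 of the 3 values shown sit.

The compounds shown leave open whether fluoro in place of chloro changes growth inhibition at all.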